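The compounds below may be only part of what the source reports. "The series", "measured", "known", "first", "only" and "open" are said of these compounds alone.

Measured in an ADME assay on Vero cells (Chlorocebus sabaeus) for cytotoxicity, read by reporter gene assay, with a stated time of 4 days; on this read-out lower numbers stand for stronger inhibition and higher numbers for weaker inhibition:
- Compound 1 `CCCCCC(=O)NCC(C)(C)CC1=C(O)C(=O)c2ccccc2C1=O`: 46600 nM
- Compound 2 `CCCCCCC(=O)NCC(C)(C)CC1=C(O)C(=O)c2ccccc2C1=O`: 24800 nM
- Compound 3 `CCCCCCC(=O)OCC(C)(C)CC1=C(O)C(=O)c2ccccc2C1=O`: 99300 nM

Compound 3 has the highest number of the three, which here means the weakest inhibition. It sits above its two neighbours, with a 2.1-fold higher number from compound 1 to compound 3 (0.33 log units; beyond the scatter) and a 4.0-fold higher number from compound 2 to compound 3 (0.60 log units; beyond the scatter). Both of these steps swap the link that joins the chain to the rest of the molecule, and compound 4 leaves that link untouched, so they say little about what comes next.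

Compound 4 `CCCCCCCCCCC(=O)OCC(C)(C)CC1=C(O)C(=O)c2ccccc2C1=O` keeps the link of compound 3 and extends its chain. The change is butyl in place of hydrogen on a saturated chain carbon, six bonds along the chain from a carbonyl carbon.

For the measured compounds named here, the only measured step that lengthens a chain is a 1.9-fold lower number from compound 1 to compound 2 (0.27 log units; within the scatter). It is a methyl rather than a butyl, it stays within the scatter, and it was seen with the other link, so it offers only weak guidance. Since a butyl is a much larger addition than the methyl of that step, a modest move toward a lower number is expected, though with wide uncertainty.

The expected change is a 2.5-fold lower number from compound 3 to compound 4 (0.39 log units; beyond the scatter).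

For compound 4 the estimated value is 40000 nM, with an expected range of 12000 nM to 120000 nM.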

Compound 4, half-maximal inhibitory concentration: > 233000 nM
Compound 4 gave a limit, no number (the forecaster's own chance of this, stated with the estimate: 20%); middle value at least 5.8-fold (0.76 log units) away from the limit.
By their numbers in this assay, from the lowest: compounds 2 and 1 (each within the scatter of the next); then compound 3. At a limit, above all of these: compound 4.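

In this assay, compound 4 gives > 233000 nM, which is a limit of the assay and not a number. Placing a butyl on a saturated chain carbon, six bonds along the chain from a carbonyl carbon, is an at least 2.3-fold higher number from compound 3 to compound 4 (0.37 log units; beyond the scatter), so on the ester link this longer chain goes toward weaker inhibition, while the only earlier chain extension, made with a methyl on the amide link, was a 1.9-fold lower number from compound 1 to compound 2 (0.27 log units; within the scatter) and gave no clear direction. The new step gives only a minimum size, so compound 4 can be placed above compound 3 but at no definite distance from it: the limit of > 233000 nM in this assay, at which 1 of the 4 values shown sits.

Going by these compounds, it remains open whether a smaller addition at this same place, such as an ethyl or a propyl, would already shift the read-out or would leave it within the scatter of compound 3. Also open, on these data alone, is whether a longer chain on the amide link of compound 2 would act as it does here, and how an amine or a hydroxyl group in place of the butyl would read.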